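This account rests on a few compounds, and the source may have more. Where it says the series, first, only, none or still open, it means among the compounds named here.

Measured compounds:
- compound 1 `CCOC(=O)Cn1ncc2c(Nc3ccc(NC(=O)CCl)cc3)ncnc21`: in a functional assay on cells (Homo sapiens) for inhibition, read by MTT assay, with a stated time of 72 h (a higher number here means a weaker inhibitor, a lower number a stronger inhibitor), compound 1 gives 7.27 ug/mL
- compound 2 `O=C(O)Cn1ncc2c(Nc3ccc(NS(=O)(=O)c4ccc([N+](=O)[O-])cc4)cc3)ncnc21`: compound 2 reaches only the limit > 100 ug/mL in this assay, which is a limit and not a number
- compound 3 `CC(=O)Nc1ccc(Nc2ncnc3c2cnn3CC(=O)O)cc1`: compound 3 likewise reaches only the limit > 64 ug/mL in this assay, again a limit and not a number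

Compound 1 is therefore the only one of the three with a measured number in this assay; the other two stand at a limit (the limit of > 100 ug/mL in this assay, at which 1 of the 3 values shown sits, and (the limit of > 64 ug/mL in this assay, at which 1 of the 3 values shown sits)). For the measured compounds named here, no single-change step between measured compounds is available, so no measured step size can be reported.

Compound 4 `CCOC(=O)Cn1ncc2c(Nc3ccc(NC(=O)c4ccccc4)cc3)ncnc21` differs from compound 1 by the change phenyl in place of chloromethyl on a carbonyl carbon. Compounds 2 and 3, which carry other groups on that aryl nitrogen, show only limits, but each also differs from compound 1 elsewhere, so they give no clean comparison. He expects compound 4 to be a weaker inhibitor than compound 1, with a step of a 5.5-fold higher number from compound 1 to compound 4 (0.74 log units; beyond the scatter) beyond the usual scatter, and estimates for compound 4 a value of 40 ug/mL (range 10 ug/mL to 100 ug/mL), with a fair chance that only a limit is reported.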

Compound 4, half-maximal inhibitory concentration: > 100 ug/mL
Compound 4 gave a limit, no number; the forecaster's own chance of this, stated with the estimate: 40%; middle value at least 2.5-fold (0.39 log units) from the limit.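

For the compounds shown here, this is the first clean comparison at this position: with the ethyl ester and the shared core unchanged, phenyl in place of chloromethyl on a carbonyl carbon gives an at least 13-fold higher number from compound 1 to compound 4 (1.13 log units; beyond the scatter). The change is large, so this carbonyl substituent strongly affects the result, which compounds 2 and 3 could not show since each also differs from compound 1 elsewhere. In this assay compound 4 gives > 100 ug/mL, which is a limit and not a number, so the full size of the step remains unknown: the limit of > 100 ug/mL in this assay, at which 2 of the 4 values shown sit.

The compounds shown leave open whether the number of compound 1 goes with the chlorine or with the small size of the group, which a bromomethyl group or a cyclopropyl ring on that carbonyl carbon would help to separate. They also leave open how a longer chloroalkyl chain would read at this position.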